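Swapping the Ring on the Amide Carbonyl

The source may report more compounds than this note shows. Statements on the series, on what has been measured and on what is new or still open speak of the compounds shown alone.

Compound 1 `Cc1cnc(C(=O)Nc2cc(Cl)cc3cccnc23)cn1` and compound 2 `O=C(Nc1cc(Cl)cc2cccnc12)c1ncccn1` share one core, while compound 3 `Cc1cnc(C(=O)Nc2cc(OCCNC(=O)OC(C)(C)C)cc3cccnc23)cn1` and compound 4 `CC(C)(C)OC(=O)NCCOc1cc(NC(=O)c2ncccn2)c2ncccc2c1` share another; the difference between the two cores is not broken down here. In a functional assay on PANC-1 cells (Homo sapiens) for inhibition, read by MTT assay, with a stated time of 72 h (on this read-out higher numbers stand for weaker inhibition and lower numbers for stronger inhibition), compound 1 gives 1770 nM, and compound 2 gives 4670 nM. The change between them is pyrimidin-2-yl in place of 5-methylpyrazin-2-yl on a carbonyl carbon and it made a step of a 2.6-fold higher number from compound 1 to compound 2 (0.42 log units; beyond the scatter). Compound 3 gives 2170 nM in this assay. Compound 4 carries the same change on its own core, (pyrimidin-2-yl in place of 5-methylpyrazin-2-yl on a carbonyl carbon), at a place described in identical words. A step of roughly the same size, a 2.6-fold higher number from compound 3 to compound 4 (0.41 log units; beyond the scatter), is expected because the matching step a 2.6-fold higher number from compound 1 to compound 2 (0.42 log units; beyond the scatter) went beyond the scatter. Compound 4 is therefore estimated at 5600 nM, with a likely range from 3000 nM to 10500 nM.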

Compound 4, half-maximal inhibitory concentration: > 10000 nM
Compound 4 ended at the assay's limit; the forecaster's own chance of this, stated with the estimate: 5%; at least 1.7-fold (0.25 log units) between middle value and limit.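

In this assay, pyrimidin-2-yl in place of 5-methylpyrazin-2-yl gave weaker inhibition on the second core too, with an at least 4.6-fold higher number from compound 3 to compound 4 (0.66 log units; beyond the scatter). Compound 4 gives > 10000 nM, which is a limit of the assay and not an exact number. The direction of the change therefore carried over between these two cores, but its size on the second core stays unfixed, and nothing shows whether the two steps truly differ: the same change on two cores in this assay, a 2.6-fold higher number (0.42 log units; beyond the scatter) from compound 1 to compound 2 and an at least 4.6-fold higher number (0.66 log units; beyond the scatter) from compound 3 to compound 4; the limit leaves it open whether they differ.

Going by these compounds, whether the same direction holds on any further core remains open. Also open, on these data alone, is how the change behaves when a free amine replaces the chlorine of compound 1, or when a plain phenyl ring sits on the carbonyl carbon.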